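The source may hold more compounds than are shown below. What is called first, only, known or untested is meant among the compounds shown, and "the series" means these compounds.

In a functional assay on A549 cells (Homo sapiens) for inhibition, read by CCK-8 assay, with a stated time of 72 h, tested at 1 uM (on this read-out higher numbers stand for more inhibition of growth at the one concentration tested and lower numbers for less inhibition of growth), compound 1 `CN(C)C(=O)c1cc2cnc(Nc3ccc(NC(=O)C4(C(=O)Nc5ccc(F)cc5)CC4)cc3)nc2n1C1CCCC1` gives 86.6%, compound 2 `CN(C)C(=O)c1cc2cnc(Nc3ccc(NC(=O)C4(C(=O)Nc5cccc(Cl)c5)CC4)cc3)nc2n1C1CCCC1` gives 8.3%, and compound 3 `CN(C)C(=O)c1cc2cnc(Nc3ccc(NC(=O)C4(C(=O)Nc5ccc(Br)cc5)CC4)cc3)nc2n1C1CCCC1` gives -6.6%, the lowest of the three. The next structure, compound 4 `COC(=O)c1cccc(NC(=O)C2(C(=O)Nc3ccc(Nc4ncc5cc(C(=O)N(C)C)n(C6CCCC6)c5n4)cc3)CC2)c1`, differs from it as follows: 3-(methoxycarbonyl)phenyl in place of 4-bromophenyl on an amide-type nitrogen. In words, this is 3-(methoxycarbonyl)phenyl in place of 4-bromophenyl on an amide-type nitrogen. Three measured steps at this same place bear on the change: a number 78.3 percentage points lower from compound 1 to compound 2 (beyond the scatter), a number 93.2 percentage points lower from compound 1 to compound 3 (beyond the scatter) and a number 14.9 percentage points lower from compound 2 to compound 3 (beyond the scatter). Only compound 1 stands high, so a large rise is not the likeliest outcome, although these steps show that large moves occur here. The closest comparison is the 3-chlorophenyl of compound 2 at 8.3%. A modest rise is therefore expected, namely a number 21.6 percentage points higher from compound 3 to compound 4 (beyond the scatter). For compound 4 the estimated value is 15%, with an expected range from -8% to 60%.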

Compound 4, percent growth inhibition at one concentration: 10.5%
Compound 4: middle estimate off by 4.5 percentage points, on the high side; measured number inside the range.
By their numbers in this assay, from the lowest: compound 3; then compounds 2 and 4 (each within the scatter of the next); then compound 1.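

The 3-(methoxycarbonyl)phenyl group on the amide-type nitrogen stays far from the 4-fluorophenyl result, with a number 76.1 percentage points lower from compound 1 to compound 4 (beyond the scatter) and only a number 17.1 percentage points higher from compound 3 to compound 4 (beyond the scatter) against the 4-bromophenyl. Methoxycarbonyl in place of chloro on an aromatic carbon gives a number 2.2 percentage points higher from compound 2 to compound 4 (within the scatter) so these two groups cannot be told apart here, and the hydrogen-bond acceptors that enter with the ester do not bring back the high number. Nothing measured beyond these numbers accounts for the steps.

From the compounds shown here alone, whether 4-fluorophenyl alone holds the high number remains open. A carboxylic acid in place of the methoxycarbonyl, or an amine on that phenyl ring, would test this further.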